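The compounds below may be only part of what the source reports. "The series", "measured", "known", "first", "only" and "open" are said of these compounds alone.

Two compounds sharing a core have numbers in a functional assay on the whole organism with Mus musculus as the target, in the maximal electroshock model, with a stated time of 2 h; a higher number here means that more compound is needed for the effect, a lower number that less compound is needed. Compound 1 `CCCC(COC(=O)Nc1ccc(S(N)(=O)=O)cc1)C(C)CC` gives 136 mg/kg, and compound 2 `CCC(C)C(C)OC(=O)Nc1ccc(S(N)(=O)=O)cc1` gives 31 mg/kg. Compound 2 therefore holds the lower of the two numbers, meaning that less of it is needed for the effect, and its gap to compound 1 lies beyond the scatter.

The account now turns to compound 3 `CCC(C)CCOC(=O)Nc1ccc(S(N)(=O)=O)cc1`, which has the same atoms as compound 2, joined differently. It carries 3-methylpentyl in place of 1,2-dimethylbutyl on an oxygen next to a carbonyl group. Going by the values given here, no measured pair shows a change of this kind, so the data give no direct guide to its size. The expectation therefore starts from compound 2 at 31 mg/kg, and it allows for the much higher number of compound 1 at 136 mg/kg. In this assay, no step beyond the scatter is expected, with only a slight lean towards a higher number. The estimate amounts to an expected step of a 1.3-fold higher number from compound 2 to compound 3 (0.11 log units; within the scatter). For compound 3 the expected value is 40 mg/kg, with an estimated range from 15 mg/kg to 100 mg/kg.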

Compound 3, dose for half-maximal effect: 14 mg/kg
For compound 3 the middle estimate is 2.9-fold (0.46 log units) above the measured one; measured number below the stated range.
By their numbers in this assay, from the lowest: compound 3; then compound 2; then compound 1.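

In this assay, 3-methylpentyl in place of 1,2-dimethylbutyl on an oxygen next to a carbonyl group gives a 2.2-fold lower number from compound 2 to compound 3 (0.35 log units; beyond the scatter). This shows that the number at this position depends on how the six carbons are joined, even though the atoms stay the same and neither group has a ring, a hydrogen-bond donor or acceptor, or a charge. Hydrogen in place of propyl on a saturated chain carbon bound to two saturated chain carbons gives a 9.7-fold lower number from compound 1 to compound 3 (0.99 log units; beyond the scatter), so less compound is needed without that propyl group, and no information on hand explains either step.

The compounds shown leave open how a straight hexyl chain, a shorter butyl chain or a cyclohexyl ring on this oxygen would compare with 3-methylpentyl. They also leave open whether a chain carrying an amine or a carboxylic acid would keep a number as low as that of compound 3 at 14 mg/kg.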